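This account rests on a few compounds, and the source may have more. Where it says the series, first, only, none or still open, it means among the compounds named here.

The series shares one core, shown in compound 1 `CN(C)CCn1cnnc1-c1cc(Oc2ccc(NC(=O)N/N=C/c3cccc(Br)c3)cc2F)ccn1`, compound 2 `CN(C)CCn1cnnc1-c1cc(Oc2ccc(NC(=O)N/N=C/c3ccc(O)c(O)c3)cc2F)ccn1`, and compound 3 `CN(C)CCn1cnnc1-c1cc(Oc2ccc(NC(=O)N/N=C/c3ccc(O)cc3)cc2F)ccn1`, with the arylidene part at the far end of the hydrazone varied from one member to the next. In an ADME assay on WI-38 cells (Homo sapiens) for cytotoxicity, read by MTT assay, with a stated time of 72 h (a higher number here means a weaker inhibitor, a lower number a stronger inhibitor), compound 1 gives 4230 nM. For compound 2 the result in this assay is "not determined" (no result reported), and compound 3 in this assay likewise stands at "not determined" (no result reported), so compound 3 has no single number to anchor it; the only figure in the set belongs to compound 1, with one further entry beside compound 3 that also carries no single number.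

Compound 4 `CN(C)CCn1cnnc1-c1cc(Oc2ccc(NC(=O)N/N=C/c3ccccc3O[N+](=O)[O-])cc2F)ccn1` is the next member to be tested. Against compound 3 the change is 2-(nitrooxy)phenyl in place of 4-hydroxyphenyl on a carbon with a double bond to nitrogen. Going by the values given here, with no measured pair of this kind to draw on, and with compound 3 itself unnumbered, the size and direction of any step into compound 4 cannot be read from the data; the only reference is compound 1 at 4230 nM, a member of the same core in the same assay. On that basis compound 4 is expected to lie in the same broad region, near 5000 nM, with a plausible range from 1500 nM to 20000 nM, acknowledging that the assay may report only a limit rather than a number.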

Compound 4, half-maximal inhibitory concentration: 6860 nM
For compound 4 the middle estimate is 1.4-fold (0.14 log units) below the measured one; low and high end bracket the measured number.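

In this assay, going by these compounds alone, placing 2-(nitrooxy)phenyl instead of 3-bromophenyl on a carbon with a double bond to nitrogen gives a 1.6-fold higher number from compound 1 to compound 4 (0.21 log units; within the scatter), the first step that can be read at all. It shows that these two aryl groups, which differ in the atoms they carry, are not told apart by this read-out, so the shared core now has two numbers that sit within the usual scatter of each other, though two compounds cannot establish a trend for this position. No measured evidence bears on why the two groups fall together, and that question stays without an answer here.

The steps into compound 2 and compound 3, and from them to compound 4, cannot be read, so the 4-hydroxyphenyl group and the catechol-type dihydroxyphenyl group of compound 2 remain unplaced against the others. Going by these compounds, it also remains open whether a quite different group at this place, such as an amine or a carboxylic acid on the phenyl ring, or a longer chain in place of the ring, would move the number beyond the scatter.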